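This account rests on a few compounds, and the source may have more. Where it says the series, first, only, none or still open, it means among the compounds named here.

Compound 1 `COCCn1nc(C(=O)N[C@H]2COc3ccccc3N(C)C2=S)nc1Cc1ccccc1` stands second highest of the three numbers measured in a functional assay on HT-29 cells (Homo sapiens) for inhibition, read by luminescence and CellTiter-Glo, with a stated time of 24 h (a higher number here means that more compound is needed for the effect, a lower number that less compound is needed), where compound 1 gives 566 nM. Compound 2 `CN1C(=S)[C@@H](NC(=O)c2nc(Cc3ccccc3)n(CCCO)n2)COc2ccccc21` gives 209 nM, and compound 3 `CN1C(=S)[C@@H](NC(=O)c2nc(Cc3ccccc3)n(CCCCC#N)n2)COc2ccccc21` gives 2680 nM. The steps are a 2.7-fold lower number from compound 1 to compound 2 (0.43 log units; beyond the scatter), a 4.7-fold higher number from compound 1 to compound 3 (0.68 log units; beyond the scatter) and a 13-fold higher number from compound 2 to compound 3 (1.11 log units; beyond the scatter). Compound 4 `CN1C(=S)[C@@H](NC(=O)c2nc(Cc3ccccc3)n(C3CCN(C(=O)OC(C)(C)C)C3)n2)COc2ccccc21` differs from compound 1 by a group of 12 heavy atoms (9 carbon, 1 nitrogen, 2 oxygen; one five-membered non-aromatic ring with 1 hetero atom) in place of a group of 4 heavy atoms (3 carbon, 1 oxygen; no ring), on an aromatic nitrogen. All three measured steps alter the group on that same aromatic nitrogen, so all bear on this change; they show that the position responds to alteration in both directions, with a large spread between compound 2 and compound 3. None of them, however, brings in a ring or a group of this size, so the measured steps give only a loose guide. Compound 4 is expected to lie near compound 1 or somewhat higher, and the step of a 1.8-fold higher number from compound 1 to compound 4 (0.25 log units; within the scatter) is the expectation. Compound 4 is estimated at 1000 nM, with a range from 200 nM to 5000 nM.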

Compound 4, half-maximal effective concentration: > 10000 nM
Compound 4: only a limit was reported; the forecaster's own chance of this, stated with the estimate: 10%; middle value at least 10-fold (1.00 log units) away from the limit.
By their numbers in this assay, from the lowest: compound 2; then compound 1; then compound 3. At a limit, above all of these: compound 4.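

In this assay compound 4 stands at a limit, not at a number: the limit of > 10000 nM in this assay, at which 1 of the 4 values shown sits. The steps to it are therefore minimum sizes: an at least 17-fold higher number from compound 1 to compound 4 (1.24 log units; beyond the scatter), an at least 47-fold higher number from compound 2 to compound 4 (1.67 log units; beyond the scatter) and an at least 3.7-fold higher number from compound 3 to compound 4 (0.57 log units; beyond the scatter). The earlier open chains on the aromatic nitrogen moved the number in both directions, whereas this group of 12 heavy atoms with a five-membered non-aromatic ring gives a limit beyond all three of their values, which shows that this change can cost far more than the chain changes suggested.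

The compounds shown do not separate the ring from the rest of the group, since both enter together. From the compounds shown here alone, it also stays open whether a free amine on that ring, or a longer chain ending in hydroxy, would bring the number down.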